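Cytotoxicity notes: aryl replaced by benzyl at the fused core

This account rests on a few compounds, and the source may have more. Where it says the series, first, only, none or still open, it means among the compounds named here.

Of the compounds shown here, three with a shared core have been measured in an ADME assay on HepG2 cells (Homo sapiens) for cytotoxicity, read by luminescence, CellTiter-Glo and ATP content, with a stated time of 72 h; on this read-out lower numbers stand for an effect already at smaller amounts and higher numbers for an effect only at larger amounts of compound. Compound 1 `c1ccc(-c2ccc3c(NCCCNCc4ccco4)ccnc3c2)cc1` gives 5920 nM and compound 2 `COc1ccc(Oc2ccc3c(NCCCNCc4cccc(OC)c4O)ccnc3c2)cc1` gives 5500 nM. Compound 3 `COc1cccc(CNCCCNc2ccnc3cc(-c4ccc(C(F)(F)F)cc4)ccc23)c1O` gives 2210 nM, the lowest of the three numbers; its nearest neighbour is compound 2 and its furthest compound 1, both beyond the scatter. For the measured compounds named here, the only measured step at the same position is a 2.5-fold lower number from compound 2 to compound 3 (0.40 log units; beyond the scatter), which shows that exchanging the group on this aromatic carbon can move the read-out beyond the scatter. Compound 4 `COc1cccc(CNCCCNc2ccnc3cc(Cc4ccc(F)cc4)ccc23)c1O` differs from compound 3 by 4-fluorobenzyl in place of 4-(trifluoromethyl)phenyl on an aromatic carbon. Compound 1 and compound 2, neither of which carries 4-(trifluoromethyl)phenyl, sit within the scatter of each other. Going by the values given here, no measured step covers the aryl-to-benzyl exchange itself, so the direction rests only on this pattern. For compound 4 the expected step is a 1.8-fold higher number from compound 3 to compound 4 (0.26 log units; within the scatter), back toward the numbers of compounds 1 and 2. For compound 4 the estimate in this assay is 4000 nM, with a range from 1800 nM to 9000 nM.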

Compound 4, half-maximal effective concentration: 4780 nM
Beside the measured number, compound 4's estimate is 1.2-fold (0.08 log units) below it, within the range that was stated.
By their numbers in this assay, from the lowest: compound 3; then compounds 4, 2 and 1 (each within the scatter of the next).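

The aryl-to-benzyl exchange now has its own measured result: it gives a 2.2-fold higher number from compound 3 to compound 4 (0.34 log units; beyond the scatter) in this assay and so moves the read-out away from the lowest number in the set. Exchanging 4-methoxyphenoxy for 4-fluorobenzyl on the same aromatic carbon gives a 1.2-fold lower number from compound 2 to compound 4 (0.06 log units; within the scatter) and leaves these two groups indistinguishable here, so among the three groups compared at this position, only 4-(trifluoromethyl)phenyl stands apart. The data at hand offer no explanation for these steps.

The change to compound 4 alters both the attachment of the ring and its ring substituent, so the contribution of each remains unresolved. A fluorophenyl group and a trifluoromethylbenzyl group on this aromatic carbon would separate the two contributions.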